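Hexyl in Place of Methyl on the Fluorobenzyl Core

This account rests on a few compounds, and the source may have more. Where it says the series, first, only, none or still open, it means among the compounds named here.

Measured so far:
compound 1, `CCCCCCNc1nc(-c2ccccc2)nc2c1nnn2Cc1ccccc1Cl`: 31000000 nM
compound 2, `Fc1ccccc1Cn1nnc2c(NC3CCCCC3)nc(-c3ccccc3)nc21`: 1150000 nM
compound 3, `CNc1nc(-c2ccccc2)nc2c1nnn2Cc1ccccc1F`: 25000000 nM

In an assay on isolated protein for binding affinity to adenosine receptor A1 (Bos taurus) (on this read-out higher numbers stand for weaker inhibition and lower numbers for stronger inhibition), compound 3 stands second highest of the three numbers. Its nearest neighbour is compound 1, whose value of 31000000 nM lies within the scatter of compound 3; compound 2 is far below both, and the step of a 22-fold higher number from compound 2 to compound 3 (1.34 log units; beyond the scatter) is the only one that directly bears on what the chain on the nitrogen does. Compound 4, `CCCCCCNc1nc(-c2ccccc2)nc2c1nnn2Cc1ccccc1F`, differs from compound 3 by pentyl in place of hydrogen on a saturated chain carbon bound to a nitrogen on an aromatic ring. For the measured compounds named here, no measured step covers exactly this change. The closest hint is compound 1, which carries the same hexylamino group on a core that differs only in its halogen and in this assay gives a number within the scatter of compound 3. The cyclohexyl step shows that a large ring group lowers the number strongly; whether an open hexyl chain does the same is not shown. Compound 4 is therefore expected to stay close to compound 3, with the step of a 1.7-fold lower number from compound 3 to compound 4 (0.22 log units; within the scatter) estimated to lie within or only modestly beyond the scatter. The estimate for compound 4 is 15000000 nM, in the range 3000000 nM to 50000000 nM.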

Compound 4, inhibition constant: 25000000 nM
Beside the measured number, compound 4's estimate is 1.7-fold (0.22 log units) below it, within the range that was stated.
By their numbers in this assay, from the lowest: compound 2; then compounds 3, 4 and 1 (each within the scatter of the next).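

In this assay, methyl to hexyl on the fluorobenzyl core leaves the number unmoved, no change at the digits printed from compound 3 to compound 4 (within the scatter), so this open chain does not repeat the large drop seen with the cyclohexyl group of compound 2. The ring and the open chain can now be compared directly on that core, and they stand far apart, with a 22-fold higher number from compound 2 to compound 4 (1.34 log units; beyond the scatter), which ties the low number of compound 2 to the cyclohexyl group and not simply to the size of the group on the nitrogen. With hexylamino held fixed, the halogen adds no visible difference, with a 1.2-fold lower number from compound 1 to compound 4 (0.09 log units; within the scatter), for fluoro in place of chloro on an aromatic carbon.

Where cyclopentyl, isopropyl or a longer chain such as octyl would fall on the nitrogen remains open. No measurement shown here accounts for the gap between the ring and the open chain.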